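Removing the distal ring of a biphenyl amidine

The source may report more compounds than this note shows. Statements on the series, on what has been measured and on what is new or still open speak of the compounds shown alone.

Measured compounds in an assay on cells for inhibition of Voltage-dependent T-type calcium channel subunit alpha-1H (Homo sapiens), read by patch clamp; on this read-out lower numbers stand for stronger inhibition and higher numbers for weaker inhibition:
compound 1 `O=C(CC1c2ccccc2N=C(SCCCCCN2CCCC2)N1c1ccc(-c2ccccc2)cc1)NCc1ccc(F)cc1` — 276000 nM
compound 2 `O=C(CC1c2ccccc2N=C(SCCCCCN2CCCC2)N1c1ccc(-c2ccc(F)cc2)cc1)NCc1ccc(F)cc1` — 4880 nM
compound 3 `O=C(CC1c2ccccc2N=C(SCCCCCN2CCCC2)N1c1ccc(-c2ccc(F)cc2)cc1)NCc1ccccc1` — 260 nM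

Compound 2 stands second highest of the three numbers in this assay, with compound 3 nearest and compound 1 furthest. Compound 4 `O=C(CC1c2ccccc2N=C(SCCCCCN2CCCC2)N1c1ccccc1)NCc1ccc(F)cc1` has not yet been measured; it differs from compound 2 by hydrogen in place of 4-fluorophenyl on an aromatic carbon. Within the data shown here, no measured step removes this ring whole, so the bearing is indirect. The nearest guide is a 57-fold lower number from compound 1 to compound 2 (1.75 log units; beyond the scatter), which shows that even the fluorine on this ring changes the number greatly, while a 19-fold lower number from compound 2 to compound 3 (1.27 log units; beyond the scatter) concerns the other side of the molecule. With the whole 4-fluorophenyl gone, compound 4 is expected to give a large step to higher numbers, a 20-fold higher number from compound 2 to compound 4 (1.31 log units; beyond the scatter), so compound 4 is estimated at 100000 nM, within 10000 nM to 1000000 nM.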

Compound 4, half-maximal inhibitory concentration: 57400 nM
Estimate against measurement, compound 4: 1.7-fold (0.24 log units) above; the measured number falls inside the stated range.
By their numbers in this assay, from the lowest: compound 3; then compound 2; then compound 4; then compound 1.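

In this assay, the aromatic ring at this position has no single direction of effect: taking away the 4-fluorophenyl weakens inhibition (a 12-fold higher number from compound 2 to compound 4 (1.07 log units; beyond the scatter)), whereas taking away the plain phenyl strengthens it (a 4.8-fold lower number from compound 1 to compound 4 (0.68 log units; beyond the scatter)). The bare hydrogen of compound 4 thus ranks between the two rings, so a ring here helps only in the fluorinated form shown by compound 2. Nothing measured here explains this reversal.

As far as these compounds go, whether a chloro or methoxy group in place of the fluoro would act like hydrogen or like fluoro remains open. So does whether removing the 4-fluorophenyl from compound 3 would give a similar step.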